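Formyl to Phenylimine on a Shared Pyrazole Core

The source may report more compounds than this note shows. Statements on the series, on what has been measured and on what is new or still open speak of the compounds shown alone.

Within the data shown here, in a functional assay on the whole organism (strain Wistar albino) for inhibition, with Rattus norvegicus as the target, read by paw edema, with stated times of 1 h and 3 h, at a dose of 0.32 mmol/kg by the intraperitoneal route (a higher number here means more inhibition at the dose given (going by the name of the read-out), a lower number less inhibition), compound 1 `Cc1ccc(-c2nn(-c3ccc(Cl)cc3)cc2C=O)cc1` gives 56%, the lowest of the two numbers so far; its nearest neighbour is compound 2 `COc1ccc(-c2nn(-c3ccc(Cl)cc3)cc2C=O)cc1`, which gives 57.6%, and the step of a number 1.6 percentage points higher from compound 1 to compound 2 (within the scatter) lies within the scatter. Compound 3 `Cc1ccc(-c2nn(-c3ccc(Cl)cc3)cc2/C=N\c2ccccc2)cc1` differs from compound 1 by a group of 8 heavy atoms (7 carbon, 1 nitrogen; one six-membered aromatic ring of carbon only) in place of a group of 2 heavy atoms (1 carbon, 1 oxygen; no ring), on an aromatic carbon. Among the measured compounds shown here, no measured step exchanges the formyl group, so the one step known offers no guide to this change. Compound 3 is therefore expected to stand close to compound 1, with a step of a number 1 percentage points lower from compound 1 to compound 3 (within the scatter) that stays within the scatter, and its estimate in this assay is 55%, ranging from 40% to 70%.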

Compound 3, a percentage reported as inhibition, in the whole organism at one dose (the size of the read-out at that dose, not a potency): 49.3%
For compound 3 the middle estimate is 5.7 percentage points above the measured one, and the stated range covers the measured number.
By their numbers in this assay, from the lowest: compounds 3, 1 and 2 (each within the scatter of the next).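

The exchange at this aromatic carbon, the first measured there, gives in this assay a number 6.7 percentage points lower from compound 1 to compound 3 (within the scatter). A group of 8 heavy atoms with one six-membered aromatic ring can therefore stand in place of the formyl group while the read-out stays within the scatter at this dose. Nothing measured bears on why this is so. On these data alone, whether a carboxylic acid or an amine on this carbon would give a similar number stays open. So does whether a methoxy group on the new phenyl ring would.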